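Oxan-4-yl in Place of Isopropyl on a Fused Core

This account rests on a few compounds, and the source may have more. Where it says the series, first, only, none or still open, it means among the compounds named here.

Two compounds of a shared core have been run in an ADME assay on the whole organism (Hepatocyte, Rattus norvegicus, strain Han Wistar) for metabolic stability; a lower number here means slower removal, a higher number faster removal of the compound. Compound 1 `COC(=O)N1CCN([C@H]2CC[C@H](Nc3ncnn4ccc([C@H](C)CC(N)=O)c34)CC2)CC1` gives 17 uL/min in this assay. Compound 2 `CC(=O)N1CCN([C@H]2CC[C@H](Nc3ncnn4ccc(C(C)C)c34)CC2)CC1` gives 18 uL/min in this assay, the highest of the two numbers recorded, though the gap to compound 1 lies within the usual scatter, so the two cannot be told apart on these data.

Compound 3 `CC(=O)N1CCN([C@H]2CC[C@H](Nc3ncnn4ccc(C5CCOCC5)c34)CC2)CC1` has not yet been measured. It differs from compound 2 in one place: oxan-4-yl in place of isopropyl on an aromatic carbon. Within the data shown here, no pair of measured compounds shows what this change does in this assay, so no measured step can guide the expectation, and compound 1 shows only a different group at that same position of the core.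

Compound 3 is therefore estimated at 14 uL/min in this assay, with a range from 7 uL/min to 28 uL/min. The expected step of a 1.3-fold lower number from compound 2 to compound 3 (0.11 log units; within the scatter) is small and is thought likely to stay within the scatter, with no clear direction claimed.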

Compound 3, intrinsic clearance in a liver preparation (reported as CLH), per the amount of preparation that the assay uses: 3.5 uL/min
Estimate against measurement, compound 3: 4.0-fold (0.60 log units) above, outside the stated range (below it).
By their numbers in this assay, from the lowest: compound 3; then compounds 1 and 2 (each within the scatter of the next).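

In this assay, the aromatic carbon two ring bonds from the ring nitrogen proves sensitive to the group it carries: oxan-4-yl in place of isopropyl gives a 5.1-fold lower number from compound 2 to compound 3 (0.71 log units; beyond the scatter) on an otherwise unchanged compound. The earlier compounds shown here could not show this, as no measured pair differed only at this position. This single pair shows the size and direction of the step for this change, but no available evidence explains it.

The change brings in a ring and an oxygen together, so the compounds shown leave open which of the two goes with the lower number; a cyclohexyl group at this position, which has the ring without the oxygen, would separate them. On these data alone, whether the step holds with a different group on the piperazine nitrogen also remains open.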